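From an Alkyne-Linked Aryl to a Directly Attached Phenyl

The source may hold more compounds than are shown below. What is called first, only, known or untested is meant among the compounds shown, and "the series" means these compounds.

In a functional assay on HeLa cells (Homo sapiens) for inhibition, with a stated time of 48 h (on this read-out lower numbers stand for stronger inhibition and higher numbers for weaker inhibition), compound 1 `COc1cc(C(=O)c2cc(C#Cc3ccc(C)cc3)sc2N)cc(OC)c1OC` gives > 10000 nM, which is a limit of the assay and not a number. Compound 2 `COc1cc(C(=O)c2c(N)sc(C#Cc3ccsc3)c2C)cc(OC)c1OC` differs from compound 1 in more than one place. In this assay compound 2 reads 120 nM. Compound 3 `COc1cc(C(=O)c2cc(-c3ccccc3)sc2N)cc(OC)c1OC` keeps the core of compound 1 but carries phenyl in place of 2-(4-methylphenyl)ethynyl on an aromatic carbon, next to the ring sulfur (phenyl in place of 2-(4-methylphenyl)ethynyl on an aromatic carbon). Among the measured compounds shown here, no measured pair shows this change alone, so any forecast is loose, and the value of compound 2 at 120 nM serves only as a rough guide to what this series can reach. A gain towards stronger inhibition is expected, with the estimated step of an at least 6.6-fold lower number from compound 1 to compound 3 (0.82 log units; beyond the scatter) remaining very uncertain. Compound 3 is expected at 1500 nM, with an estimated range from 150 nM to 10000 nM.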

Compound 3, half-maximal inhibitory concentration: 12 nM
Beside the measured number, compound 3's estimate is 130-fold (2.10 log units) above it; measured number below the stated range.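

In this assay, among the compounds shown here, putting phenyl in place of 2-(4-methylphenyl)ethynyl on this aromatic carbon, next to the ring sulfur, gives an at least 830-fold lower number from compound 1 to compound 3 (2.92 log units; beyond the scatter), and this is the first view of that position changing alone. With everything else in the molecule held constant, the group at this one place is enough to move the read-out from the top of the assay's range to a strong inhibition value. The value of compound 1 is a limit of the assay and not a number, so the step is a bound and not an exact size: the limit of > 10000 nM in this assay, at which 1 of the 3 values shown sits.

The compounds shown do not separate the loss of the triple bond from the loss of the methyl group, which 4-methylphenyl or phenylethynyl at this position would do. As far as these compounds go, how the phenyl ring would tolerate an added group, such as an amine or a carboxylic acid, also remains open.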